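Trimming piperidin-3-yl to aminomethyl in compound 1

The compounds below may be only part of what the source reports. "The series", "measured", "known", "first", "only" and "open" are said of these compounds alone.

Measured in a functional assay on U-87MG ATCC cells for inhibition, with U-87 MG (Homo sapiens) as the target, read by MTT assay, with a stated time of 72 h; a lower number here means a stronger inhibitor, a higher number a weaker inhibitor:
- compound 1 `COc1ccccc1-c1csc2cnc(Nc3ccc(NC(=O)[C@H]4CCCNC4)cc3)nc12` gives 300 nM 
- compound 2 `COc1ccccc1-c1csc2cnc(Nc3ccc(C(=O)NC4CCNCC4)c(C)c3)nc12` gives 460 nM 
- compound 3 `COc1ccccc1-c1csc2cnc(Nc3ccc(C(=O)NC4CCNCC4)cc3C)nc12` gives 250 nM 

The value of compound 1 lies within the usual scatter of the values of both compound 2 and compound 3, so these three numbers cannot be told apart. The next molecule is compound 4 `COc1ccccc1-c1csc2cnc(Nc3ccc(NC(=O)CN)cc3)nc12`, which has not yet been measured. The change from compound 1 is aminomethyl in place of piperidin-3-yl on a carbonyl carbon. Among the measured compounds shown here, no two measured compounds differ in only one place, so the data give no direct size for such a change. All three measured compounds carry a six-membered non-aromatic ring, and compound 4 has no such ring, so its result is uncertain. In this assay a modest move towards a weaker inhibitor is expected, a little beyond the scatter, with the estimated step being a 2.7-fold higher number from compound 1 to compound 4 (0.43 log units; beyond the scatter). The estimate for compound 4 is 800 nM (range 250 nM to 2500 nM) .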

Compound 4, half-maximal inhibitory concentration: 210 nM
For compound 4 the middle estimate is 3.8-fold (0.58 log units) above the measured one; measured number outside the range, below it.
By their numbers in this assay, from the lowest: compounds 4, 3, 1 and 2 (each within the scatter of the next, the first and the last beyond it).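

In this assay, putting aminomethyl in place of piperidin-3-yl on the carbonyl carbon gives (a 1.4-fold lower number from compound 1 to compound 4 (0.15 log units; within the scatter)), so this change cannot be said to move the number in either direction. Among the compounds shown here, this pair gives the first direct reading at this position: the six-membered non-aromatic ring and its defined stereocentre are both gone, the group is left with far fewer heavy atoms, and the number stays within the scatter. No measurement shown here explains this result.

This single pair cannot show whether the same holds for other groups at this position. An aminoethyl chain, or a carboxylic acid in place of the amine, would test whether a longer chain is tolerated and whether the amine nitrogen is needed for a number in this range.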